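Hydroxamic acid series: methylphenyl position swap on triazole

A few compounds are considered here, and "the series" means these few. Any claim that something is new, unique, unknown or untested is made for them only; others in the source may bear on it.

Measured so far:
compound 1 `Cc1ccc(-c2nc(CNc3ccc(C(=O)NO)cc3)n(-c3ccccc3)n2)o1` gives 60.7%
compound 2 `O=C(NO)c1ccc(NCc2nc(-c3cccnc3)nn2-c2ccccc2)cc1` gives 57.7%
compound 3 `Cc1ccc(-c2nc(CNc3ccc(C(=O)NO)cc3)n(-c3ccccc3)n2)cc1` gives 62.2%

All three were read in an assay on Sf9 cells for inhibition of protein deacetylase HDAC6 (Homo sapiens), read by fluorescence, with a stated time of 40 min, tested at 100 nM; a lower number here means less inhibition, a higher number more inhibition at the concentration tested (going by the name of the read-out). The number for compound 3 is the largest of the three, but the steps of a number 1.5 percentage points higher from compound 1 to compound 3 (within the scatter) and a number 4.5 percentage points higher from compound 2 to compound 3 (within the scatter) are both within the scatter, so the three compounds are not separated by this read-out. The third measured step, a number 3 percentage points lower from compound 1 to compound 2 (within the scatter), is likewise within the scatter.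

Compound 4 `Cc1ccccc1-c1nc(CNc2ccc(C(=O)NO)cc2)n(-c2ccccc2)n1` differs from compound 3 only in the group on the triazole carbon: 2-methylphenyl in place of 4-methylphenyl on an aromatic carbon. Among the compounds with values here, none of the measured steps moves a methyl group around a phenyl ring; each exchanges one aromatic group for a different one, and each of those exchanges stayed within the scatter. The available data therefore give no reason to expect a step beyond the scatter for this smaller rearrangement either.

Compound 4 is expected to give about 58% in this assay, with a range of 45% to 70%, which means an expected step of a number 4.2 percentage points lower from compound 3 to compound 4 (within the scatter).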

Compound 4, a percentage reported as inhibition, at one concentration (the size of the read-out at that concentration, not a potency): 53.2%
Beside the measured number, compound 4's estimate is 4.8 percentage points above it; the measured number falls inside the stated range.
By their numbers in this assay, from the lowest: compounds 4, 2, 1 and 3 (each within the scatter of the next).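

In this assay, shifting the methyl group on the phenyl ring at this carbon of the five-membered aromatic ring gives a number 9 percentage points lower from compound 3 to compound 4 (within the scatter), so the read-out does not separate 2-methylphenyl from 4-methylphenyl here. The 2-methylphenyl group is not separated from the other two groups at this carbon either, with a number 4.5 percentage points lower from compound 2 to compound 4 (within the scatter) and a number 7.5 percentage points lower from compound 1 to compound 4 (within the scatter). All four aromatic groups at this position therefore remain within the scatter of one another, and no measurement at hand bears on the reason for this.

On these data alone, it remains open whether a group of another kind on this carbon, such as an amine, a carboxylic acid or a longer alkyl chain, would give a step beyond the scatter. A reading at a single concentration also leaves any difference in potency among these compounds open.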